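This account rests on a few compounds, and the source may have more. Where it says the series, first, only, none or still open, it means among the compounds named here.

In an ADME assay on a cell-free system (plasma, Homo sapiens) for metabolic stability, read by LC-MS (on this read-out higher numbers stand for a longer-lived compound and lower numbers for a shorter-lived compound), three compounds sharing one core have been measured: compound 1 `NCc1ccc(C(=O)Nc2ccncc2F)cc1-c1cccc(C(=O)Oc2ccccc2)c1` gives 0.117 h, compound 2 `CCCOC(=O)c1cccc(-c2cc(C(=O)Nc3ccncc3F)ccc2CN)c1` gives 0.317 h, and compound 3 `COC(=O)c1cccc(-c2cc(C(=O)Nc3ccncc3F)ccc2CN)c1` gives 1.08 h, the highest of the three. Compound 4 `NCc1ccc(C(=O)Nc2ccncc2F)cc1-c1cccc(C(=O)O)c1` has not yet been measured. It differs from compound 3 as follows: hydrogen in place of methyl on an oxygen next to a carbonyl group. This is hydrogen in place of methyl on an oxygen next to a carbonyl group, or methoxycarbonyl to carboxy. The measured steps bearing on it change the group on that same oxygen: a 2.7-fold higher number from compound 1 to compound 2 (0.43 log units; beyond the scatter), a 9.2-fold higher number from compound 1 to compound 3 (0.97 log units; beyond the scatter) and a 3.4-fold higher number from compound 2 to compound 3 (0.53 log units; beyond the scatter). All three are modest rises as the group goes from phenyl through propyl to methyl. Continuing that direction, a rise at least as large is expected, estimated as a 7.4-fold higher number from compound 3 to compound 4 (0.87 log units; beyond the scatter). For compound 4 the estimated half-life is 8 h, with an expected range from 2 h to 30 h.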

Compound 4, half-life: > 2 h
Compound 4 gave a limit, no number (the forecaster's own chance of this, stated with the estimate: 40%); the middle value does not contradict the limit.
By their numbers in this assay, from the lowest: compound 1; then compound 2; then compound 3. At a limit, above all of these: compound 4.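

In this assay compound 4, with hydrogen in place of methyl on an oxygen next to a carbonyl group, gives a limit and not a number: the limit of > 2 h in this assay, at which 1 of the 4 values shown sits. The order seen from phenyl through propyl to methyl extends to hydrogen on the two wider steps, an at least 6.3-fold higher number from compound 2 to compound 4 (0.79 log units; beyond the scatter) and an at least 17-fold higher number from compound 1 to compound 4 (1.23 log units; beyond the scatter). The step to the nearest compound is only a floor, an at least 1.8-fold higher number from compound 3 to compound 4 (0.26 log units; that floor lies within the scatter), so the limit alone does not separate compound 4 from compound 3.

From the compounds shown here alone, how far compound 4 lies past its limit remains open. Also open, going by these compounds, is whether an amide in place of the carboxy group, or an isopropyl group on that oxygen, would fit the same order.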